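Removing the methoxy group from an anilino-pyrimidine growth inhibitor

The source may hold more compounds than are shown below. What is called first, only, known or untested is meant among the compounds shown, and "the series" means these compounds.

Compound 1 `COc1cccc(Nc2ncc3c(n2)CCCC3)c1` carries a methoxy group on its aniline ring. In a functional assay on MV4-11 cells (Homo sapiens) for inhibition, read by resazurin assay, with a stated time of 72 h (a higher number here means a weaker inhibitor of growth, a lower number a stronger inhibitor of growth), compound 1 gives 2280 nM. Among the measured compounds shown here, the only other measured compound, compound 2 `Cc1cccc(Nc2ncc3c(n2)CCCC3)c1`, differs from it in one place; in this assay compound 2 gives 3290 nM. For the measured compounds named here, the step of a 1.4-fold higher number from compound 1 to compound 2 (0.16 log units; within the scatter) lies within the scatter, so the two numbers cannot be told apart, and compound 1 is simply the one of the pair with the lower number.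

Compound 3 `c1ccc(Nc2ncc3c(n2)CCCC3)cc1` has not been measured. It differs from compound 1 by hydrogen in place of methoxy on an aromatic carbon. Going by the values given here, the one step that bears on this change is the exchange at the same aromatic carbon, a 1.4-fold higher number from compound 1 to compound 2 (0.16 log units; within the scatter), which stayed within the scatter when a methyl took the place of the methoxy. A group of similar size there apparently made little difference, and removing the group entirely is expected to behave in much the same way, with no step beyond the scatter in either direction. Compound 3 is therefore estimated at 3000 nM, within a range of 1200 nM to 7500 nM, corresponding to an expected step of a 1.3-fold higher number from compound 1 to compound 3 (0.12 log units; within the scatter).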

Compound 3, concentration for 50% growth inhibition: 9830 nM
Beside the measured number, compound 3's estimate is 3.3-fold (0.52 log units) below it, outside the stated range (above it).
By their numbers in this assay, from the lowest: compounds 1 and 2 (each within the scatter of the next); then compound 3.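

The earlier pair showed only that methoxy and methyl could not be told apart at this aromatic carbon, which left open whether a group there matters at all. In this assay, replacing the group with hydrogen gives a 4.3-fold higher number from compound 1 to compound 3 (0.63 log units; beyond the scatter) and also a 3.0-fold higher number from compound 2 to compound 3 (0.48 log units; beyond the scatter), so both changes reach beyond the scatter, although both are modest. Among these three compounds, then, either group on this carbon goes with stronger growth inhibition than hydrogen alone, and nothing available here explains this difference.

Going by these compounds, it remains open whether the kind of group matters or whether almost any group on this carbon would give a similar number; a chlorine atom, a hydroxyl, an amine or a longer chain such as ethoxy at the same place would help to separate those possibilities. On these data alone, it is also open whether a methoxy or methyl group on another carbon of the same ring would lower the number as far.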